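A few compounds are considered here, and "the series" means these few. Any claim that something is new, unique, unknown or untested is made for them only; others in the source may bear on it.

Measured compounds:
- compound 1 `COc1ccc(-c2cc(-c3cc4ccccc4n3C)no2)cc1` — > 100000 nM in a functional assay on COLO 320 cells (Homo sapiens) for cytotoxicity, read by WST assay, with a stated time of 72 h; on this read-out lower numbers stand for stronger inhibition and higher numbers for weaker inhibition
- compound 2 `Cn1c(-c2cc(-c3ccc(F)cc3)no2)cc2ccccc21` — > 100000 nM in this assay

For compound 1 the value > 100000 nM is a limit of the assay, not a number. For compound 2 the value > 100000 nM is likewise a limit. Compound 2 thus stands where every value shown stands, at the limit of > 100000 nM in this assay, at which 2 of the 2 values shown sit. Compound 3 `COc1ccc(-c2cc(-c3cc4ccccc4n3C)on2)cc1` differs from compound 2 by methoxy in place of fluoro on an aromatic carbon. Within the data shown here, no measured step between two compounds exists here, so nothing shows how such a change moves this assay; no shift beyond the usual scatter is expected. Compound 3 is expected to give 150000 nM (range 50000 nM to 500000 nM), most likely again only a limit. The expected step that the limit leaves unreadable from compound 2 to compound 3 stays within the scatter.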

Compound 3, half-maximal inhibitory concentration: > 100000 nM
Compound 3 was reported as a limit (the forecaster's own chance of this, stated with the estimate: 85%); the middle value lies beyond the limit too.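

Compound 2 and compound 3 are both reported only as limits in this assay, and the step between them cannot be read. The compounds shown leave open how strongly any of them inhibits, and whether methoxy in place of fluoro changes anything.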